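Fluorine removal on the benzamide of compound 1

This account rests on a few compounds, and the source may have more. Where it says the series, first, only, none or still open, it means among the compounds named here.

Measured so far:
compound 1, `O=C(Nc1cccc(-c2oc3cc(-c4ccc(F)cc4)ccc3c(=O)c2O)c1)c1ccc(F)cc1F`: 20500 nM
compound 2, `COc1ccccc1C(=O)Nc1cccc(-c2oc3cc(-c4ccc(F)cc4)ccc3c(=O)c2O)c1`: 11700 nM
compound 3, `Cc1ccccc1C(=O)Nc1cccc(-c2oc3cc(-c4ccc(F)cc4)ccc3c(=O)c2O)c1`: 17600 nM

All three share the same core and differ only in the ring on the carbonyl carbon of the amide. Within the data shown here, in a functional assay on A549 cells (Homo sapiens) for antiproliferative activity, read by CCK-8 assay, with a stated time of 72 h (on this read-out lower numbers stand for stronger inhibition and higher numbers for weaker inhibition), compound 1 gives 20500 nM; no other measured compound differs from it beyond the scatter, as the steps of a 1.8-fold lower number from compound 1 to compound 2 (0.24 log units; within the scatter) and a 1.2-fold lower number from compound 1 to compound 3 (0.07 log units; within the scatter) show. Compound 4, `O=C(Nc1cccc(-c2oc3cc(-c4ccc(F)cc4)ccc3c(=O)c2O)c1)c1cccc(F)c1`, is not yet measured; it differs from compound 1 as follows: 3-fluorophenyl in place of 2,4-difluorophenyl on a carbonyl carbon. The two steps that replace the same 2,4-difluorophenyl bear directly on this change, and both stayed within the scatter. A step of similar size, a 1.2-fold lower number from compound 1 to compound 4 (0.08 log units; within the scatter), is therefore expected, with no direction beyond the scatter. Compound 4 is estimated at 17000 nM, within 8000 nM to 36000 nM.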

Compound 4, half-maximal inhibitory concentration: 15400 nM
Beside the measured number, compound 4's estimate is 1.1-fold (0.04 log units) above it; the range from low to high includes it.
By their numbers in this assay, from the lowest: compounds 2, 4, 3 and 1 (each within the scatter of the next).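

In this assay the step to a single fluorine on the ring stays within the scatter: a 1.3-fold lower number from compound 1 to compound 4 (0.12 log units; within the scatter). The same holds against the two rings without fluorine, with a 1.1-fold lower number from compound 3 to compound 4 (0.06 log units; within the scatter) and a 1.3-fold higher number from compound 2 to compound 4 (0.12 log units; within the scatter). On this carbonyl carbon, all four substituted phenyl rings therefore read alike, with no step beyond the scatter. No available evidence bears on this flat picture.

Still open, from the compounds shown here alone, is whether anything other than a substituted phenyl ring on this carbonyl carbon, such as a saturated amine like piperidine or a longer chain, or a carboxylic acid on the ring, would give a step beyond the scatter.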